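The source may report more compounds than this note shows. Statements on the series, on what has been measured and on what is new or still open speak of the compounds shown alone.

Measured compounds:
In a functional assay on DU-145 cells (Homo sapiens) for inhibition, read by trypan blue exclusion, with a stated time of 72 h (on this read-out higher numbers stand for weaker inhibition and lower numbers for stronger inhibition), compound 1 `Cn1c(=O)c(S(=O)(=O)c2ccc(F)cc2[N+](=O)[O-])cc2cnc(Nc3ccc4[nH]ccc4c3)nc21` gives 1500 nM.
In this assay compound 2 `Cn1c(=O)c(S(=O)(=O)c2ccc(C(=O)O)cc2)cc2cnc(Nc3ccc4[nH]ccc4c3)nc21` gives 10000 nM.
In this assay compound 3 `Cn1c(=O)c(S(=O)(=O)c2ccc(Cl)cc2)cc2cnc(Nc3ccc4[nH]ccc4c3)nc21` gives 250 nM.

Compound 3 stands lowest of the three, with the step of a 6.0-fold lower number from compound 1 to compound 3 (0.78 log units; beyond the scatter) and the step of a 40-fold lower number from compound 2 to compound 3 (1.60 log units; beyond the scatter) both beyond the scatter. Compound 4 `Cn1c(=O)c(S(=O)(=O)c2ccc(O)cc2)cc2cnc(Nc3ccc4[nH]ccc4c3)nc21` differs from compound 3 in one place: hydroxy in place of chloro on an aromatic carbon.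

Among the compounds with values here, the step that bears most directly on this change is the one from compound 2 to compound 3, where a carboxy on the same aromatic carbon gave a 40-fold lower number from compound 2 to compound 3 (1.60 log units; beyond the scatter). The step of a 6.0-fold lower number from compound 1 to compound 3 (0.78 log units; beyond the scatter) shows that other replacements of the chloro have also raised the number. Within the data shown here, no measured compound carries a hydroxy here, so the size for compound 4 can only be placed between those cases. A rise in this assay beyond the scatter is therefore expected for compound 4, though smaller than the carboxy step; the expected step is an 8.0-fold higher number from compound 3 to compound 4 (0.90 log units; beyond the scatter). Compound 4 is estimated at 2000 nM, with a range from 500 nM to 8000 nM.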

Compound 4, half-maximal inhibitory concentration: 250 nM
Beside the measured number, compound 4's estimate is 8.0-fold (0.90 log units) above it; the whole stated range lies above it.
By their numbers in this assay, from the lowest: compounds 3 and 4 (each within the scatter of the next); then compound 1; then compound 2.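

In this assay, hydroxy in place of chloro on this aromatic carbon, para to a large group, leaves the read-out where it was (no change at the digits printed from compound 3 to compound 4 (within the scatter)), so the number at this position does not separate these two single-atom substituents, even though only hydroxy carries a hydrogen-bond donor. The carboxy of compound 2 now stands apart from both, since hydroxy in its place also gives a large drop (a 40-fold lower number from compound 2 to compound 4 (1.60 log units; beyond the scatter)), and the 4-hydroxyphenyl group likewise gives a lower number than the 4-fluoro-2-nitrophenyl group (a 6.0-fold lower number from compound 1 to compound 4 (0.78 log units; beyond the scatter)). No measurement is available here to account for hydroxy and chloro matching while carboxy does not.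

On these data alone, it remains open whether an amine, a methoxy group or a longer chain on this carbon would read like chloro and hydroxy or like carboxy. As far as these compounds go, whether chloro and hydroxy also match on other cells remains open as well.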